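This account rests on a few compounds, and the source may have more. Where it says the series, first, only, none or still open, it means among the compounds named here.

Among the measured compounds shown here, compound 3 `CCOc1nc(Cl)cc(NC(=O)NCc2cc(C)c(-c3cn(C)nc3C(F)(F)F)nn2)c1C` stands lowest of the three numbers so far in a functional assay on HFL1 cells for antagonist activity at sphingosine 1-phosphate receptor 2 (Homo sapiens), read by ELISA, with a stated time of 24 h, in the presence of a further agent that is not named here (on this read-out higher numbers stand for weaker inhibition and lower numbers for stronger inhibition), where compound 3 gives 32000 nM. Compound 1 `CCOc1cc(NC(=O)NCc2cc(C)c(-c3cn(C)nc3C(F)(F)F)nn2)cc(C#N)n1` gives 67000 nM in this assay, and compound 2 `CCOc1cc(NC(=O)NCc2cc(C)c(-c3cn(C)nc3C(F)(F)F)nn2)cc(C)n1` gives 194000 nM. The step from compound 1 to compound 3 was a 2.1-fold lower number from compound 1 to compound 3 (0.32 log units; beyond the scatter), and the step from compound 2 to compound 3 was a 6.1-fold lower number from compound 2 to compound 3 (0.78 log units; beyond the scatter). Compound 4 `CCOc1nc(C#N)cc(NC(=O)NCc2cc(C)c(-c3cn(C)nc3C(F)(F)F)nn2)c1C` differs from compound 3 by cyano in place of chloro on an aromatic carbon. For the measured compounds named here, no measured step swaps chloro for cyano on its own, so the nearest bearing comes from a 2.9-fold higher number from compound 1 to compound 2 (0.46 log units; beyond the scatter), in which methyl in place of cyano raised the number, meaning the cyano-bearing compound 1 gave the lower number of that pair. On that basis a modest step is expected in this assay for compound 4, tending toward a lower number but possibly staying within the scatter. Compound 4 is therefore estimated at 25000 nM, with a range from 8000 nM to 80000 nM. That estimate is expected to amount to a 1.3-fold lower number from compound 3 to compound 4 (0.11 log units; within the scatter).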

Compound 4, half-maximal inhibitory concentration: 17000 nM
Compound 4: middle estimate off by 1.5-fold (0.17 log units), on the high side; measured number inside the range.
By their numbers in this assay, from the lowest: compounds 4 and 3 (each within the scatter of the next); then compound 1; then compound 2.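

In this assay, cyano in place of chloro on the aromatic carbon next to the ring nitrogen gives a 1.9-fold lower number from compound 3 to compound 4 (0.27 log units; within the scatter), so the two groups are not told apart at this position when the methyl group is present. Methyl in place of hydrogen on an aromatic carbon, with the cyano group kept, gives a 3.9-fold lower number from compound 1 to compound 4 (0.60 log units; beyond the scatter); this is the only step shown that isolates the added methyl, which came together with the chloro change in the step to compound 3. No measurement offered here accounts for either step.

From the compounds shown here alone, whether an amine, a carboxylic acid or a methoxy group at the cyano position would separate from chloro and cyano remains open. So does whether an ethyl group in place of the added methyl would carry the step further.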